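This account rests on a few compounds, and the source may have more. Where it says the series, first, only, none or still open, it means among the compounds named here.

In a physicochemical assay for lipophilicity, using the shake flask method (on this read-out higher numbers stand for higher lipophilicity and lower numbers for lower lipophilicity), compound 1 `CC(C)Oc1cc(Oc2ccc(S(C)(=O)=O)cc2)cc(-c2nccc(=O)[nH]2)c1` gives 2.14 and is not separated beyond the scatter from either of the other two measured compounds. Compound 2 `COc1cnc(-c2cc(Oc3ccc(S(C)(=O)=O)cc3)cc(OC(C)C)c2)[nH]c1=O` gives 2.21 in the same measurement, and compound 3 `CC(C)Oc1cc(Oc2ccc(S(C)(=O)=O)cc2)cc(-c2ncc(Cl)c(=O)[nH]2)c1` gives 2.04 there. Methoxy in place of hydrogen on an aromatic carbon amounts to a number 0.07 log units higher from compound 1 to compound 2 (within the scatter) in this series, and chloro in place of hydrogen on an aromatic carbon amounts to a number 0.10 log units lower from compound 1 to compound 3 (within the scatter) here.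

The next step leads to compound 4 `CNS(=O)(=O)c1ccc(Oc2cc(OC(C)C)cc(-c3nccc(=O)[nH]3)c2)cc1` and puts methylamino in place of methyl on a sulfonyl sulfur as the single structural difference. The same difference reads methylsulfonyl to methylsulfamoyl. Going by the values given here, none of the measured steps touches the sulfonyl sulfur, and no measured compound carries methylsulfamoyl, so they offer only a loose guide to its size. Even chloro in place of methoxy on an aromatic carbon, at a number 0.17 log units lower from compound 2 to compound 3 (within the scatter) in this set, is a small step. No step beyond the scatter is therefore expected, and the direction remains unsupported by measurement. The estimated change is a number 0.16 log units higher from compound 1 to compound 4 (within the scatter) on present evidence. The estimate for compound 4 is 2.3 with an expected range from 1.95 to 2.65 in this assay once measured.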

Compound 4, distribution coefficient: 2.63
Beside the measured number, compound 4's estimate is 0.33 log units below it; measured number inside the range.
By their numbers in this assay, from the lowest: compounds 3, 1 and 2 (each within the scatter of the next); then compound 4.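

In this assay the change at the sulfonyl sulfur gives a number 0.49 log units higher from compound 1 to compound 4 (beyond the scatter) and so is a modest step beyond the scatter, whereas the three steps on an aromatic carbon among compounds 1, 2 and 3 all stay within it. This position is therefore the first place in the series where one change separates two compounds on this read-out, and the direction is upward, with methylamino entering in place of methyl and bringing one nitrogen and one hydrogen-bond donor. No measurement shown here accounts for the size or direction of this step.

As far as these compounds go, it remains open whether the step belongs to the nitrogen, to its hydrogen or to the methyl carried on that nitrogen, and an unsubstituted amino group, a dimethylamino group or an ethylamino group on the same sulfonyl sulfur would each bear on that question. From the compounds shown here alone, it is equally open whether methylamino gives a step of similar size when the methoxy of compound 2 or the chloro of compound 3 is present.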